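Replacing a bicyclic amine with a dimethylaminoethyl chain

A few compounds are considered here, and "the series" means these few. Any claim that something is new, unique, unknown or untested is made for them only; others in the source may bear on it.

Compound 1, `COc1cc(C)c(S(=O)(=O)N(C)CCOCC(=O)N2CCN([C@@H]3CN4CCC3CC4)CC2)c(C)c1`, in an ADME assay on microsomes from liver (Homo sapiens) for metabolic stability, with a stated time of 30 min, tested at 1 uM (a lower number here means that less of the compound is left, a higher number that more of the compound is left), gives 57%.
Compound 2, `CN(Cc1ccc(C2=NCCN2)cc1)C(=O)COCCN(C)S(=O)(=O)c1ccc(OC(F)(F)F)cc1`, in this assay gives 86%.
Compound 3, `COc1cc(C)c(S(=O)(=O)N(C)CCOCC(=O)N2CCC(C3CCN(C(C)C)CC3)CC2)c(C)c1`, in this assay gives 23%.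

Among the three numbers measured, compound 1 stands second highest. Compound 2 lies higher than compound 1 by a margin beyond the usual scatter, and compound 3 lies lower than compound 1, again beyond the scatter. Compound 4, `COc1cc(C)c(S(=O)(=O)N(C)CCOCC(=O)N2CCN(CCN(C)C)CC2)c(C)c1`, keeps the core of compound 1 and differs from it in one place: a group of 5 heavy atoms (4 carbon, 1 nitrogen; no ring) in place of a group of 8 heavy atoms (7 carbon, 1 nitrogen; 2 six-membered non-aromatic rings with 1 hetero atom each), on an amine nitrogen in a ring. Within the data shown here, no measured pair of compounds shows this particular change, so the size of the step has to be judged from the structures alone. The two compounds that share the core of compound 1, compound 1 with 57% and compound 3 with 23%, differ widely from each other, which suggests that the amine portion can matter here. The step from compound 1 to compound 4 is expected to be a number 9 percentage points lower from compound 1 to compound 4 (within the scatter), a modest fall. Compound 4 is estimated at 48%, with a range from 25% to 72%.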

Compound 4, percent of the compound remaining: 84%
Compound 4: the middle estimate sits 36 percentage points below what was measured; measured number outside the range, above it.
By their numbers in this assay, from the lowest: compound 3; then compound 1; then compounds 4 and 2 (each within the scatter of the next).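

In this assay, placing 2-(dimethylamino)ethyl on the amine nitrogen in a ring, where the bicyclic amine stood, gives a number 27 percentage points higher from compound 1 to compound 4 (beyond the scatter). Among these compounds, this is the first single change that can be read, and it shows that the group at this one position can by itself move the amount of compound remaining beyond the scatter, with the smaller, ring-free group giving the higher number. Nothing at hand accounts for this rise.

The compounds shown do not tell whether the gain comes with losing the rings in general or belongs to this particular chain. A longer chain such as 3-(dimethylamino)propyl, or a single methyl group on the same nitrogen, would help to separate those two readings.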